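A few compounds are considered here, and "the series" means these few. Any claim that something is new, unique, unknown or untested is made for them only; others in the source may bear on it.

Compound 1, with the structure `O=S(=O)(c1ccc(F)cc1)c1cnc2cc(F)ccc2c1-c1ccc(Cl)cc1`, sets the reference point. In an assay (strain Sprague-Dawley) for displacement of a labelled ligand from metabotropic glutamate receptor 5 (Rattus norvegicus), with a stated time of 60 min (on this read-out higher numbers stand for weaker inhibition and lower numbers for stronger inhibition), compound 1 gives 38.6 nM, the lowest of the two numbers recorded here. Its nearest neighbour, compound 2 `O=S(=O)(c1ccc(F)cc1)c1cnc2cc(Cl)ccc2c1-c1ccc(Cl)cc1`, differs only in carrying chloro in place of fluoro on an aromatic carbon of the shared core, and in this assay compound 2 gives 110 nM; the step of a 2.8-fold higher number from compound 1 to compound 2 (0.45 log units; beyond the scatter) lies beyond the usual scatter of repeated measurements. A third member, compound 3 `N#Cc1ccc2c(-c3ccc(Cl)cc3)c(S(=O)(=O)c3ccc(F)cc3)cnc2c1`, carries a nitrile on the same core, but for compound 3 this assay reports "not determined" (no result reported), so no number is available.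

The compound still to be measured is compound 4 `O=S(=O)(c1ccc(F)c(Cl)c1)c1cnc2cc(F)ccc2c1-c1ccc(Cl)cc1`. It differs from compound 1 by chloro in place of hydrogen on an aromatic carbon, that is, the sulfonyl-bearing 4-fluorophenyl becomes 3-chloro-4-fluorophenyl. Going by the values given here, none of the measured steps touches this part of the molecule: the only step recorded, from compound 1 to compound 2, concerns the core, not the sulfonyl aryl group, so it gives no direct guide. With no evidence either way, the expectation for this assay is a step of about a 1.0-fold higher number from compound 1 to compound 4 (0.02 log units; within the scatter), meaning no change beyond the scatter. Compound 4 is therefore estimated at 40 nM, within a range of 14 nM to 120 nM.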

Compound 4, inhibition constant: 8.3 nM
Compound 4: the middle estimate sits 4.8-fold (0.68 log units) above what was measured; measured number below the stated range.
By their numbers in this assay, from the lowest: compound 4; then compound 1; then compound 2.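

Going by these compounds alone, the sulfonyl-bearing aryl ring, which no earlier step touched, turns out to be a place where one added atom counts: in this assay, going from 4-fluorophenyl to 3-chloro-4-fluorophenyl gives a 4.7-fold lower number from compound 1 to compound 4 (0.67 log units; beyond the scatter) and so stronger inhibition, from a single chloro placed on a carbon that carried only hydrogen. Chloro therefore does not act in one direction across these compounds, since chloro in place of fluoro on the shared core gave a 2.8-fold higher number from compound 1 to compound 2 (0.45 log units; beyond the scatter) whereas chloro in place of hydrogen on the sulfonyl-bearing ring lowers the number, although these two steps differ both in the place changed and in the atom replaced. Nothing shown here explains why the added chloro strengthens inhibition.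

As far as these compounds go, whether chloro is special at this carbon stays open, as a methyl group, a methoxy group, a bromo group or an amine in the same place could give a smaller step, a larger one or none. Also open, from the compounds shown here alone, is whether the gain depends on the fluoro group ortho to it, and whether it would carry over to the core of compound 2.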